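The source may report more compounds than this note shows. Statements on the series, on what has been measured and on what is new or still open speak of the compounds shown alone.

- compound 1 `COc1ccc(/C=C/C(=O)c2ccc(OC)c3c2OC(C)(C)C=C3)cc1OCCO`: 8750 nM
- compound 2 `COc1ccc(/C=C/C(=O)c2ccc(OC)c3c2OC(C)(C)C=C3)cc1OC(=O)C1CC1`: 410 nM

In a functional assay on K562 cells (Homo sapiens) for cytotoxicity, read by MTT assay (on this read-out lower numbers stand for stronger inhibition and higher numbers for weaker inhibition), compound 2 at 410 nM holds the lower of the two numbers. Compound 3 `COc1ccc(/C=C/C(=O)c2ccc(OC)c3c2OC(C)(C)C=C3)cc1OC(=O)c1ccc(Br)cc1` differs from it by 4-bromophenyl in place of cyclopropyl on a carbonyl carbon, with 4-bromophenyl in place of cyclopropyl on a carbonyl carbon. Among the measured compounds shown here, the only measured step, a 21-fold lower number from compound 1 to compound 2 (1.33 log units; beyond the scatter), is large, but it exchanged the whole group on an oxygen on an aromatic ring. For the measured compounds named here, no measured pair varies the group on the carbonyl carbon, so only a modest change is expected, slightly toward a higher number. The expected change is a 1.5-fold higher number from compound 2 to compound 3 (0.17 log units; within the scatter). For compound 3, the estimated value is 600 nM, within a range of 200 nM to 2000 nM.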

Compound 3, half-maximal inhibitory concentration: 1110 nM
Beside the measured number, compound 3's estimate is 1.9-fold (0.27 log units) below it, and the stated range covers the measured number.
By their numbers in this assay, from the lowest: compound 2; then compound 3; then compound 1.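

In this assay, the group on the carbonyl carbon proves to matter: 4-bromophenyl in place of cyclopropyl gives a 2.7-fold higher number from compound 2 to compound 3 (0.43 log units; beyond the scatter). Even so, (4-bromophenyl)carbonyl in place of 2-hydroxyethyl on the oxygen gives a 7.9-fold lower number from compound 1 to compound 3 (0.90 log units; beyond the scatter), so the gain over compound 1 does not depend on cyclopropyl alone. Nothing available explains either step. Going by these compounds, it remains open whether the bromine or the six-membered aromatic ring accounts for the difference between compound 2 and compound 3. On these data alone, what a plain phenyl, an amine or a butyl chain on the carbonyl carbon would give also remains open.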